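Coumarin Ethers: Replacing an Amide Side Chain with Carboxy

This account rests on a few compounds, and the source may have more. Where it says the series, first, only, none or still open, it means among the compounds named here.

Measured compounds:
- compound 1, `COc1cc(=O)oc2cc(OCc3cccc(Br)c3)ccc12`: 27%
- compound 2, `CNC(=O)COc1cc(=O)oc2cc(OCc3cccc(Cl)c3)ccc12`: 11%

In an assay on isolated protein (strain Sprague-Dawley) for inhibition of Amine oxidase [flavin-containing] A (Rattus norvegicus), read by spectrophotometry, with a stated time of 5 min, tested at 10 uM (on this read-out higher numbers stand for more inhibition at the one concentration tested (going by the name of the read-out) and lower numbers for less inhibition), compound 1 reaches 27%. In this assay compound 2 gives 11%, the lower of the two measured numbers, and the gap to compound 1 lies beyond the usual scatter. Compound 3, `O=C(O)c1cc(=O)oc2cc(OCc3cccc(Cl)c3)ccc12`, has not yet been measured. Relative to compound 2 it differs in one place: carboxy in place of (methylcarbamoyl)methoxy on an aromatic carbon. For the measured compounds named here, no measured pair of compounds shows a step of this kind, so there is nothing to suggest a direction for it. On that basis compound 3 is expected to stay close to compound 2, with a step of a number 1 percentage points higher from compound 2 to compound 3 (within the scatter) that is not expected to exceed the scatter. In this assay compound 3 is therefore estimated at 12%, within a range from 0% to 30%.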

Compound 3, a percentage reported as inhibition, at one concentration (the size of the read-out at that concentration, not a potency): 0%
Compound 3: the middle estimate sits 12 percentage points above what was measured; the measured number falls inside the stated range.
By their numbers in this assay, from the lowest: compound 3; then compound 2; then compound 1.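

At the aromatic carbon opposite the ring oxygen, this assay now gives a first one-place comparison: carboxy in place of (methylcarbamoyl)methoxy brings a number 11 percentage points lower from compound 2 to compound 3 (beyond the scatter). So what sits at this position can change the read-out, and this change moves it downward, with compound 3 at 0% on this single-concentration test. No measurement shown offers a reason for this drop.

Still open, on these data alone, is whether the fall follows the carboxy group itself or the loss of the longer side chain, a question that a carboxymethoxy chain or a simple primary amide on the same carbon could help separate. Compound 1 differs from compound 2 and compound 3 in more than one place, so its methoxy group gives no clean comparison with either side chain.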